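The source may hold more compounds than are shown below. What is called first, only, known or untested is meant among the compounds shown, and "the series" means these compounds.

Compound 1 `Brc1cn2ccnc2c(-c2ccc3ncn(C4CCCCC4)c3c2)n1` gives 12% in a functional assay on EKVX cells (Homo sapiens) for inhibition, read by sulforhodamine B assay, with a stated time of 48 h, tested at 10 uM; a lower number here means less inhibition, a higher number more inhibition at the concentration tested (going by the name of the read-out).
Compound 2 `COc1ccc(-c2cn3ccnc3c(-c3ccc4ncn(C5CCCCC5)c4c3)n2)cc1` gives 56.7% in this assay.

In this assay, for the measured compounds named here, compound 2 stands highest of the two numbers; its nearest neighbour is compound 1, and the only measured step, a number 44.7 percentage points higher from compound 1 to compound 2 (beyond the scatter), is large and beyond the scatter. Compound 3 `c1ccc2c(-c3cn4ccnc4c(-c4ccc5ncn(C6CCCCC6)c5c4)n3)cccc2c1` differs from compound 2 by naphthalen-1-yl in place of 4-methoxyphenyl on an aromatic carbon. The step from compound 1 to compound 2 is the only one that touches this position, and it shows that putting an aromatic ring where the bromo sat raises the read-out a great deal. Going by the values given here, no measured step compares one aromatic ring with another at this carbon, so the size of the change from 4-methoxyphenyl to naphthalen-1-yl is not anchored by data. Compound 3 is therefore expected to stay close to compound 2, with a step of a number 6.7 percentage points lower from compound 2 to compound 3 (within the scatter) that may well lie within the scatter, and its value is estimated at 50% with a range from 28% to 72%.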

Compound 3, a percentage reported as inhibition, at one concentration (the size of the read-out at that concentration, not a potency): 13.3%
The estimate for compound 3 lay 36.7 percentage points above the measured number; measured number below the stated range.
By their numbers in this assay, from the lowest: compounds 1 and 3 (each within the scatter of the next); then compound 2.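

The change at this aromatic carbon shows that an aromatic ring in place of the bromo is not enough by itself: in this assay there is a number 43.4 percentage points lower from compound 2 to compound 3 (beyond the scatter) when naphthalen-1-yl replaces 4-methoxyphenyl, so these two groups are far from interchangeable here. Against the original bromo, there is a number 1.3 percentage points higher from compound 1 to compound 3 (within the scatter) with naphthalen-1-yl, so among the three groups shown, only 4-methoxyphenyl goes with a clearly higher read-out. Nothing available here explains the difference between these groups.

As far as these compounds go, what an unsubstituted phenyl or a 4-aminophenyl group would give at this carbon remains open, and with it whether the read-out of compound 2 depends on the methoxy group or on the single ring that carries it. From the compounds shown here alone, whether the same ranking would hold at other concentrations or in other cell lines also remains open.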